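A few compounds are considered here, and "the series" means these few. Any claim that something is new, unique, unknown or untested is made for them only; others in the source may bear on it.

Measured compounds in a functional assay on DU-145 cells (Homo sapiens) for cytotoxicity, read by MTT assay; on this read-out higher numbers stand for weaker inhibition and lower numbers for stronger inhibition:
compound 1, `CC(O)(CSc1ccccc1)c1nc(-c2ccccc2)no1`, gives > 100000 nM.
compound 2, `CC(O)(CSc1ccccc1)c1nc(-c2ccc(F)c(Cl)c2)no1`, gives 5500 nM.
compound 3, `CC(O)(CSc1ccc(Cl)cc1)c1nc(-c2ccc([N+](=O)[O-])c(C(F)(F)F)c2)no1`, gives 1300 nM.

The value of compound 1, > 100000 nM, is a limit of this assay rather than a number, as the limit of > 100000 nM in this assay, at which 1 of the 3 values shown sits, records. Of the two numbers that were obtained, compound 3 gives the lower one; compound 2 sits nearest to it, and the gap between the two lies beyond the usual scatter.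

Among the measured compounds shown here, the one measured step, an at least 18-fold lower number from compound 1 to compound 2 (1.25 log units; beyond the scatter), changes the aryl group on the aromatic carbon of the shared core. Compound 2 and compound 3 differ in two places at once, so their values can only be compared as they stand.

Compound 4, `CC(O)(CS(=O)(=O)c1ccccc1)c1nc(-c2ccc([N+](=O)[O-])c(C(F)(F)F)c2)no1`, has not been measured. It differs from compound 3 by phenylsulfonyl in place of (4-chlorophenyl)sulfanyl on a saturated chain carbon, two bonds along the chain from an aromatic carbon and an oxygen on a saturated carbon. For the measured compounds named here, no measured step touches this part of the molecule, so there is no direct guide to the size or direction of the change in this assay.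

Compound 4 is therefore expected near 2000 nM, between 600 nM and 7000 nM. That expectation amounts to a step of a 1.5-fold higher number from compound 3 to compound 4 (0.19 log units; within the scatter), within the scatter.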

Compound 4, half-maximal inhibitory concentration: > 100000 nM
Compound 4 was reported as a limit; the forecaster's own chance of this, stated with the estimate: 5%; middle value at least 50-fold (1.69 log units) away from the limit.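

In this assay the first change measured at this place, the saturated chain carbon, gives an at least 76-fold higher number from compound 3 to compound 4 (1.88 log units; beyond the scatter) and so shows that this part of the molecule cannot be altered freely. Phenylsulfonyl in place of (4-chlorophenyl)sulfanyl is therefore a large loss on this read-out, and its true size remains unknown. The value of compound 4 is a limit of the assay and not a number: the limit of > 100000 nM in this assay, at which 2 of the 4 values shown sit.

This single change swaps the sulfanyl link for a sulfonyl link and also removes the chlorine, so the compounds shown cannot say which of the two matters, and a (4-chlorophenyl)sulfonyl or a plain phenylsulfanyl group on the same core would separate them. Also open, going by these compounds, is how an amine or an ether oxygen in place of the sulfur would read.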